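The source may hold more compounds than are shown below. What is called first, only, known or untested is meant among the compounds shown, and "the series" means these compounds.

Compound 1 `CC(CCC(=O)O)Cc1cccc(OCc2ccc3ccccc3n2)c1`: 140 nM
Compound 2 `c1ccc2nc(COc3ccc(OCCCc4nnn[nH]4)cc3)ccc2c1`: 69 nM

In an assay on membranes from lung (Cavia porcellus) for binding affinity to cysteinyl leukotriene receptor (Homo sapiens) (a lower number here means a stronger inhibitor, a higher number a weaker inhibitor), compound 2 gives the lowest of the two numbers, and compound 1 stands higher by a margin beyond the usual scatter. Compound 3 `CC(CCC(=O)O)Cc1ccc(OCc2ccc3ccccc3n2)cc1` has not yet been measured. It differs from compound 2 in one place: 4-carboxy-2-methylbutyl in place of 3-(1H-tetrazol-5-yl)propoxy on an aromatic carbon. Within the data shown here, no measured pair isolates this exchange. The only reference for the entering group is compound 1, which carries it on another aromatic carbon and gives 140 nM in this assay. Compound 3 is therefore expected to give a somewhat higher number, an estimated step of a 1.6-fold higher number from compound 2 to compound 3 (0.20 log units; within the scatter). The estimate for compound 3 in this assay is 110 nM, between 35 nM and 350 nM.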

Compound 3, inhibition constant: 43 nM
The estimate for compound 3 lay 2.6-fold (0.41 log units) above the measured number, within the range that was stated.
By their numbers in this assay, from the lowest: compounds 3 and 2 (each within the scatter of the next); then compound 1.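

In this assay, putting 4-carboxy-2-methylbutyl in place of 3-(1H-tetrazol-5-yl)propoxy on this aromatic carbon gives a 1.6-fold lower number from compound 2 to compound 3 (0.21 log units; within the scatter), so the two chains cannot be told apart here. The same chain on another aromatic carbon, in compound 1, gives 140 nM, while compound 3 gives 43 nM, so where the chain sits on the ring counts in this pair. Nothing measured here explains these results. As far as these compounds go, whether the methyl branch of the chain is needed remains open. So does whether a shorter chain ending in a carboxylic acid, or a primary amide in place of that acid, would keep the number at this position.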